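This account rests on a few compounds, and the source may have more. Where it says the series, first, only, none or still open, it means among the compounds named here.

For the measured compounds named here, compound 3 `Cn1c(-c2ccc(NC(=O)CN3CCN(c4ccccc4)CC3)cc2)nc(-c2ccccc2)c1-c1ccccc1` stands highest of the three numbers so far. In a functional assay on HT-29 cells (Homo sapiens) for cytotoxicity, read by MTT assay, with a stated time of 24 h, tested at 16 ug/mL (a lower number here means a weaker effect, a higher number a stronger effect of the compound at the concentration tested), compound 3 gives 55.4%, whereas compound 1 `CN1CCN(CC(=O)Nc2ccc(-c3nc(-c4ccccc4)c(-c4ccccc4)n3C)cc2)CC1` gives 33.7% and compound 2 `CCN1CCN(CC(=O)Nc2ccc(-c3nc(-c4ccccc4)c(-c4ccccc4)n3C)cc2)CC1` gives 28.4%. The gaps to compound 3 are real: a number 21.7 percentage points higher from compound 1 to compound 3 (beyond the scatter) and a number 27 percentage points higher from compound 2 to compound 3 (beyond the scatter), while a number 5.3 percentage points lower from compound 1 to compound 2 (within the scatter) changes little.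

Compound 4 `Cn1c(-c2ccc(NC(=O)CN3CCN(Cc4ccccc4)CC3)cc2)nc(-c2ccccc2)c1-c1ccccc1` differs from compound 3 in one place: benzyl in place of phenyl on an amine nitrogen in a ring. Going by the values given here, no measured pair shows phenyl against benzyl on this ring nitrogen. The two steps that bear on it are the moves from methyl or ethyl to phenyl, each modest and upward. Benzyl keeps the six-membered aromatic ring of carbon only but adds a chain carbon, so compound 4 is expected to sit between the alkyl-bearing compounds 1 and 2 and compound 3, most likely a modest drop, estimated as a number 10.4 percentage points lower from compound 3 to compound 4 (beyond the scatter). Compound 4 is therefore expected to give 45%, within a range from 28% to 62%.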

Compound 4, a percentage reported as activity, at one concentration (the size of the read-out at that concentration, not a potency): 37%
The estimate for compound 4 lay 8 percentage points above the measured number; the measured number falls inside the stated range.
By their numbers in this assay, from the lowest: compounds 2, 1 and 4 (each within the scatter of the next); then compound 3.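

In this assay, the change shows that the aromatic ring on this amine nitrogen is not enough to hold the higher read-out: one added chain carbon in benzyl gives a number 18.4 percentage points lower from compound 3 to compound 4 (beyond the scatter). Compound 4 also stays within the scatter of both alkyl-bearing compounds, at a number 8.6 percentage points higher from compound 2 to compound 4 (within the scatter) and a number 3.3 percentage points higher from compound 1 to compound 4 (within the scatter), so among these four compounds only phenyl, in compound 3, stands apart from the others. No measurement at hand accounts for this loss.

The compounds shown leave open whether a longer chain, such as phenylethyl, would stay at the level of compound 4, and whether a phenyl carrying fluorine or methoxy would keep the level of compound 3. They also leave open how a pyridine ring on this nitrogen would compare, and a single tested concentration gives no potency for any of them.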